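A few compounds are considered here, and "the series" means these few. Any claim that something is new, unique, unknown or untested is made for them only; others in the source may bear on it.

Compound 1 `COc1ccc(-c2nc(-c3ccccc3)c(-c3ccc4c(c3)NC(=O)CO4)[nH]2)cc1` gives 96% in a functional assay on DLD-1 cells (Homo sapiens) for cytotoxicity, read by colorimetric assay and MTT assay, with a stated time of 3 days, tested at 1 uM; on this read-out lower numbers stand for a stronger effect and higher numbers for a weaker effect at the one concentration tested. Compound 2 `O=C1COc2ccc(-c3nn(-c4ccc(F)cc4)cc3-c3ccccc3)cc2N1` gives 64.4%. Compound 3 `O=C1COc2ccc(-c3[nH]c(-c4ccccc4)nc3-c3ccccc3)cc2N1` gives 98.2%.

Compound 3 holds the highest of the three numbers: compound 1 lies nearest, within the scatter, and compound 2 lies furthest, beyond it. Compound 4 `O=C1COc2ccc(-c3[nH]c(-c4ccc(Cl)cc4Cl)nc3-c3ccccc3)cc2N1` differs from compound 3 in one place: 2,4-dichlorophenyl in place of phenyl on an aromatic carbon. Among the compounds with values here, the one measured step that bears on this is the change on the same phenyl, where a number 2.2 percentage points higher from compound 1 to compound 3 (within the scatter) stayed within the scatter. Compound 4 is therefore expected to give 92%, in the range 72% to 102%. This estimate means a step of a number 6.2 percentage points lower from compound 3 to compound 4 (within the scatter), expected to stay within the scatter.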

Compound 4, a percentage reported as activity, at one concentration (the size of the read-out at that concentration, not a potency): 97.8%
Beside the measured number, compound 4's estimate is 5.8 percentage points below it; the range from low to high includes it.
By their numbers in this assay, from the lowest: compound 2; then compounds 1, 4 and 3 (each within the scatter of the next).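

At the aromatic carbon between two ring nitrogen atoms, this assay shows a number 0.4 percentage points lower from compound 3 to compound 4 (within the scatter) for 2,4-dichlorophenyl in place of phenyl. It also shows a number 1.8 percentage points higher from compound 1 to compound 4 (within the scatter) for 2,4-dichlorophenyl in place of 4-methoxyphenyl. Phenyl, 4-methoxyphenyl and 2,4-dichlorophenyl at this position therefore cannot be told apart at the one concentration tested, and nothing measured gives a reason for this.

From the compounds shown here alone, what remains open is whether an amine or a carboxylic acid on this ring would give a step beyond the scatter. Going by these compounds, whether these three compounds separate at other concentrations also remains open.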